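A few compounds are considered here, and "the series" means these few. Any claim that something is new, unique, unknown or untested is made for them only; others in the source may bear on it.

Measured so far in a functional assay on the whole organism with Rattus norvegicus as the target; a higher number here means that more compound is needed for the effect, a lower number that less compound is needed:

compound 1 `N=c1sc2cc(OC(F)(F)F)ccc2n1CC(=O)O`: > 10 mg/kg, a limit of the assay and not a number
compound 2 `CNS(=O)(=O)CCn1c(=N)sc2cc(OC(F)(F)F)ccc21`: 4 mg/kg
compound 3 `CSCn1c(=N)sc2cc(OC(F)(F)F)ccc21`: 3 mg/kg

Compound 3 holds the lowest of the two numbers shown; the nearest is compound 2, and the step of a 1.3-fold lower number from compound 2 to compound 3 (0.12 log units; within the scatter) stays within the scatter, so no order between these two is claimed. For compound 1 only a limit is reported, (the limit of > 10 mg/kg in this assay, at which 1 of the 3 values shown sits). The two steps away from carboxy, an at least 2.5-fold lower number from compound 1 to compound 2 (0.39 log units; beyond the scatter) and an at least 3.3-fold lower number from compound 1 to compound 3 (0.52 log units; beyond the scatter), are the only ones beyond the scatter.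

Compound 4 `CS(=O)(=O)CCCn1c(=N)sc2cc(OC(F)(F)F)ccc21` has not been measured. It differs from compound 3 by 2-(methylsulfonyl)ethyl in place of methylsulfanyl on a saturated chain carbon bound to an aromatic nitrogen. Among the compounds with values here, no measured step matches this change exactly. The step of a 1.3-fold lower number from compound 2 to compound 3 (0.12 log units; within the scatter) bears on it most closely, since the (methylsulfamoyl)methyl of compound 2 is the nearest measured analogue of 2-(methylsulfonyl)ethyl at this position, and that step was within the scatter. Both routes away from carboxy gave numbers close to each other, so the expected step of a 1.3-fold higher number from compound 3 to compound 4 (0.12 log units; within the scatter) is one within the scatter, if anything toward a slightly higher number. Compound 4 is therefore expected to give about 4 mg/kg, in the range 2 mg/kg to 10 mg/kg.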

Compound 4, dose for half-maximal effect: 5 mg/kg
The estimate for compound 4 lay 1.3-fold (0.10 log units) below the measured number; the measured number falls inside the stated range.
By their numbers in this assay, from the lowest: compounds 3, 2 and 4 (each within the scatter of the next). At a limit, above all of these: compound 1.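

In this assay, 2-(methylsulfonyl)ethyl in place of methylsulfanyl gives a 1.7-fold higher number from compound 3 to compound 4 (0.22 log units; within the scatter), and (methylsulfonyl)methyl in place of methylsulfamoyl gives a 1.3-fold higher number from compound 2 to compound 4 (0.10 log units; within the scatter), so on a saturated chain carbon bound to an aromatic nitrogen a much larger group with no net charge, carrying more hydrogen-bond acceptors, is not separated from the smaller ones. The sulfur-bearing side chains of compound 2, compound 3 and compound 4 thus form one group within the scatter, and neither the size of the group nor the kind of sulfur function orders them in this assay. The step away from carboxy is weaker evidence here, at an at least 2.0-fold lower number from compound 1 to compound 4 (0.30 log units; that floor lies within the scatter), and compound 1 remains a limit of the assay and not a number: the limit of > 10 mg/kg in this assay, at which 1 of the 4 values shown sits.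

On these data alone, it remains open whether the sulfur atom matters at all, which a plain butyl chain or a methoxyethyl chain at this place would test. As far as these compounds go, it is also open whether the gap to compound 1 is specific to the carboxylic acid, which its methyl ester, a primary amide or an amine on the same chain would help to settle.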